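The source may report more compounds than this note shows. Statements on the series, on what has been measured and on what is new or still open speak of the compounds shown alone.

Going by the values given here, in an ADME assay on L132 cells (Homo sapiens) for cytotoxicity, read by MTT assay, with a stated time of 72 h (on this read-out lower numbers stand for stronger inhibition and higher numbers for weaker inhibition), compound 1 (`COc1ccc(OC)c(C2=C(c3cc(OC)c(OC)c(OC)c3)C(=O)CC2O[SiH2]C(C)(C)C)c1`) gives 100 ug/mL, the only actual number in the set. Compound 2 (`COc1ccc(C2=C(c3cc(OC)c(OC)c(OC)c3)C(=O)CC2O[SiH2]C(C)(C)C)cc1OC`) gives > 100 ug/mL, which is a limit. Compound 3 (`COc1cc(C2=C(c3ccccc3)C(O[SiH2]C(C)(C)C)CC2=O)cc(OC)c1OC`) gives > 100 ug/mL, which is also a limit. The number for compound 1 lies right at the limit of > 100 ug/mL in this assay, at which 2 of the 3 values shown sit.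

Compound 4 (`COc1ccc(OC)c(C2=C(c3cc(OC)c(OC)c(OC)c3)C(=O)CC2O)c1`) differs from compound 1 by a hydrogen atom in place of a group of 5 heavy atoms (4 carbon, 1 silicon; no ring), on an oxygen on a saturated carbon. Two measured steps start from compound 1: a number no lower from compound 1 to compound 2 (the limit leaves the size open) and a number no lower from compound 1 to compound 3 (the limit leaves the size open). Both replace the 2,5-dimethoxyphenyl on a double-bonded ring carbon and leave this oxygen untouched, so neither gives a size for the present change. The anchor is therefore compound 1 with 100 ug/mL, and nothing beyond the scatter is expected in this assay. The expected step is a 1.1-fold lower number from compound 1 to compound 4 (0.05 log units; within the scatter). Compound 4 is estimated at 90 ug/mL, with an expected range of 30 ug/mL to 200 ug/mL.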

Compound 4, half-maximal inhibitory concentration: > 100 ug/mL
Compound 4 ended at the assay's limit; the forecaster's own chance of this, stated with the estimate: 45%; middle value at least 1.1-fold (0.04 log units) away from the limit.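

Replacing the group of 5 heavy atoms (4 carbon, 1 silicon) with a hydrogen atom, on an oxygen on a saturated carbon, is the first change shown at this position, and it gives a number no lower from compound 1 to compound 4 (the limit leaves the size open). In this assay, this change therefore brings no lower number, although its size cannot be read. The series now gathers at one value: the limit of > 100 ug/mL in this assay, at which 3 of the 4 values shown sit.

Going by these compounds, whether another group on this oxygen, such as a methyl or an acetyl, would give a readable number stays open. So does the effect of an amine in place of this oxygen.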